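Aryl variation at the exocyclic alkene of the thiazolidinone

The source may report more compounds than this note shows. Statements on the series, on what has been measured and on what is new or still open speak of the compounds shown alone.

Three compounds of the series have numbers in a functional assay on HepG2 cells (Homo sapiens) for antiproliferative activity, read by MTT assay; on this read-out higher numbers stand for weaker inhibition and lower numbers for stronger inhibition. Compound 1 `O=C1N=C(N2CCC[C@H]2C(=O)Nc2ccc3ncnc(Nc4cccc(Cl)c4)c3c2)S/C1=C/c1cccnc1` gives 8500 nM. Compound 2 `O=C1N=C(N2CCC[C@H]2C(=O)Nc2ccc3ncnc(Nc4cccc(Cl)c4)c3c2)S/C1=C/c1ccccc1F` gives 18200 nM. Compound 3 `O=C1N=C(N2CCC[C@H]2C(=O)Nc2ccc3ncnc(Nc4cccc(Cl)c4)c3c2)S/C1=C/c1ccc(-c2ccccc2)cc1` gives 15400 nM. Compound 3 has the second highest of the three numbers; its nearest neighbour is compound 2, with a 1.2-fold lower number from compound 2 to compound 3 (0.07 log units; within the scatter), and its furthest is compound 1, with a 1.8-fold higher number from compound 1 to compound 3 (0.26 log units; within the scatter), so all three sit together and none is separated from the others.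

Compound 4 `O=C1N=C(N2CCC[C@H]2C(=O)Nc2ccc3ncnc(Nc4cccc(Cl)c4)c3c2)S/C1=C/c1ccc2ccccc2n1` differs from compound 3 as follows: quinolin-2-yl in place of 4-phenylphenyl on a double-bonded chain carbon bound to a double-bonded ring carbon. Going by the values given here, the steps that bear on this change are those among the three measured aryl groups: a 2.1-fold higher number from compound 1 to compound 2 (0.33 log units; beyond the scatter), a 1.8-fold higher number from compound 1 to compound 3 (0.26 log units; within the scatter) and a 1.2-fold lower number from compound 2 to compound 3 (0.07 log units; within the scatter). Only the first exceeds the scatter, and even that is modest. The change at this position therefore moves the number little, and a step in this assay no larger than the scatter is expected for compound 4, a 1.4-fold lower number from compound 3 to compound 4 (0.15 log units; within the scatter).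

Compound 4 is thus estimated at 11000 nM, with a range from 4000 nM to 30000 nM.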

Compound 4, half-maximal inhibitory concentration: 22900 nM
Compound 4: middle estimate off by 2.1-fold (0.32 log units), on the low side; the range from low to high includes it.
By their numbers in this assay, from the lowest: compounds 1, 3, 2 and 4 (each within the scatter of the next, the first and the last beyond it).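

Quinolin-2-yl stays within the scatter of the two aryl groups it is compared with here, with a 1.5-fold higher number from compound 3 to compound 4 (0.17 log units; within the scatter) and a 1.3-fold higher number from compound 2 to compound 4 (0.10 log units; within the scatter), while a 2.7-fold higher number from compound 1 to compound 4 (0.43 log units; beyond the scatter) is the widest step at this position so far, though still modest. A ring nitrogen in the aryl group therefore does not by itself go with a lower number in this assay, since compound 1 and compound 4 both carry one and yet stand furthest apart. Nothing at hand accounts for these steps.

Open, going by these compounds, is whether the gap between compound 1 and compound 4 follows the second fused ring or the place of the ring nitrogen, which pyridin-2-yl or quinolin-3-yl would help separate. Also open, on these data alone, is how this position responds to non-aromatic groups, such as a saturated cyclohexyl ring, or to an aryl ring bearing an amine or a carboxylic acid.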